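This account rests on a few compounds, and the source may have more. Where it says the series, first, only, none or still open, it means among the compounds named here.

Measured so far in an ADME assay on HEK293 cells (Homo sapiens) for cytotoxicity, read by MTT assay, with a stated time of 24 h; a higher number here means a weaker inhibitor, a lower number a stronger inhibitor:
compound 1 `CN(C)CCCNc1nc2cc([N+](=O)[O-])ccc2nc1NCc1ccc(Cl)cc1`: 10.7 ug/mL
compound 2 `CN(C)CCCNc1nc2cc([N+](=O)[O-])ccc2nc1NCc1ccc(F)cc1`: 4.28 ug/mL
compound 3 `CN(C)CCCNc1nc2cc([N+](=O)[O-])ccc2nc1NCc1ccccc1C(F)(F)F`: 24.7 ug/mL

Compound 3, at 24.7 ug/mL, holds the highest of the three numbers, and both other compounds lie beyond the scatter from it. The next compound, compound 4 `Cc1ccccc1CNc1nc2ccc([N+](=O)[O-])cc2nc1NCCCN(C)C`, keeps the shared core and changes one group: methyl in place of trifluoromethyl on an aromatic carbon.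

Going by the values given here, no measured step makes this exchange, so the evidence is indirect. Two steps lead to the 2-(trifluoromethyl)phenyl group of compound 3: a 2.3-fold higher number from compound 1 to compound 3 (0.36 log units; beyond the scatter) and a 5.8-fold higher number from compound 2 to compound 3 (0.76 log units; beyond the scatter). Both are modest and both raise the number. A third step, a 2.5-fold lower number from compound 1 to compound 2 (0.40 log units; beyond the scatter), fluoro in place of chloro, is also modest. Across these three compounds, then, changes on this aromatic ring have moved the number only modestly. Among the compounds with values here, removing the trifluoromethyl group is therefore expected to give a modest step towards a lower number, though the direction rests on just two steps and no compound yet separates the group from its place on the ring. The expected change is a 1.9-fold lower number from compound 3 to compound 4 (0.28 log units; within the scatter). Compound 4 is estimated at 13 ug/mL, with an expected range from 5 ug/mL to 30 ug/mL.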

Compound 4, half-maximal inhibitory concentration: 27.6 ug/mL
The estimate for compound 4 lay 2.1-fold (0.33 log units) below the measured number; the measured number falls inside the stated range.
By their numbers in this assay, from the lowest: compound 2; then compound 1; then compounds 3 and 4 (each within the scatter of the next).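

In this assay, the exchange at this place, on an aromatic carbon ortho to a large group, gives a 1.1-fold higher number from compound 3 to compound 4 (0.05 log units; within the scatter), so trifluoromethyl and methyl cannot be told apart here, even though the heavy atoms of the group fall from 4 to 1. The 2-methylphenyl group of compound 4 also stands apart from the 4-substituted rings, with a 6.4-fold higher number from compound 2 to compound 4 (0.81 log units; beyond the scatter) and a 2.6-fold higher number from compound 1 to compound 4 (0.41 log units; beyond the scatter), both modest steps; among these four compounds, the two with a group at the 2-position of the phenyl ring therefore carry the higher numbers, and no compound here goes against that. Nothing measured here accounts for this result.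

The compounds shown leave open whether this gap follows the place of the group on the ring or the identity of the group, and a 4-methylphenyl group could be set against compounds 1, 2 and 4 to separate the two. They also leave open whether the insensitivity at this place would hold for a methoxy group, an amine or a carboxylic acid.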